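This account rests on a few compounds, and the source may have more. Where it says the series, first, only, none or still open, it means among the compounds named here.

The series shares one core, seen in compound 1 `N#Cc1ccn2c(-c3ccccc3)c(-c3ccccc3)c(OCc3cccc(Cl)c3)c2c1`, compound 2 `Cc1ccc(S(=O)(=O)Oc2c(-c3ccccc3)c(-c3ccccc3)n3ccc(C#N)cc23)cc1` and compound 3 `COC(c1ccccc1)c1c(-c2ccccc2)c(-c2ccccc2)n2ccc(C#N)cc12`, with variation on an aromatic carbon of the five-membered aromatic ring. In an assay for inhibition of Polyunsaturated fatty acid lipoxygenase ALOX15 (Oryctolagus cuniculus) (a higher number here means a weaker inhibitor, a lower number a stronger inhibitor), compound 2 gives 25000 nM. Among the compounds with values here, for compound 1 the entry in this assay is "not determined" (no result reported), and for compound 3 the entry is "not determined" (no result reported), so compound 3 stands without a number; the only figure so far belongs to compound 2.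

Compound 4 `N#Cc1ccn2c(-c3ccccc3)c(-c3ccccc3)c(C=O)c2c1` is the next member to be tested in this assay. Relative to compound 3 the change is formyl in place of methoxy(phenyl)methyl on an aromatic carbon. Within the data shown here, no pair of measured compounds differing in one place is available to size a step of this kind, and compound 3 itself has no number to step from, so neither the direction nor the size of the change in this assay can be read from the data at hand. Among the measured compounds shown here, the only anchor is compound 2 at 25000 nM, and a weak result of that order is the simplest expectation. Compound 4 is therefore expected to come out near 20000 nM in this assay, with a wide range from 3000 nM to 100000 nM and a fair chance that only a limit is reported.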

Compound 4, half-maximal inhibitory concentration: 61000 nM
Beside the measured number, compound 4's estimate is 3.1-fold (0.48 log units) below it; the range from low to high includes it.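

In this assay the series now has its first sized change on the aromatic carbon of the five-membered aromatic ring: formyl in place of ((4-methylphenyl)sulfonyl)oxy gives a 2.4-fold higher number from compound 2 to compound 4 (0.39 log units; beyond the scatter) and this step, though modest, lies beyond the scatter, so the number at this position does respond to the group it carries. Compound 3 has no single number, and the step from it to compound 4, where the methoxy(phenyl)methyl group with its six-membered aromatic ring gives way to formyl, cannot be read; compound 1 likewise offers no comparison. The data at hand give no measured basis for explaining the difference between formyl and ((4-methylphenyl)sulfonyl)oxy.

Within the data shown here, with only two numbers at this carbon, no trend across substituents can be drawn, and it remains unknown whether any group here would move the series far from the weak values seen so far. As far as these compounds go, the response of this position to an amine, a carboxylic acid or an amide remains open, as does whether a longer chain ending in a phenyl ring would give a lower number than formyl does.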